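Acrylamide aryl variation: from compound 2 toward compound 4

The source may report more compounds than this note shows. Statements on the series, on what has been measured and on what is new or still open speak of the compounds shown alone.

Measured so far:
compound 1 `COCCOc1ccc(/C=C/C(=O)Nc2nc(-c3c(C)cc(C)cc3C)cs2)cc1` — 1490 nM
compound 2 `Cc1cc(C)c(-c2csc(NC(=O)/C=C/c3ccc(F)cc3)n2)c(C)c1` — 14000 nM
compound 3 `Cc1cc(C)c(-c2csc(NC(=O)/C=C/c3ccc(C(F)(F)F)cc3)n2)c(C)c1` — 480 nM

In a functional assay on K562 cells (Homo sapiens) for inhibition, read by MTT assay, with a stated time of 96 h (on this read-out higher numbers stand for weaker inhibition and lower numbers for stronger inhibition), compound 2 gives 14000 nM, the highest number of the three; the nearest is compound 1, and the step of a 9.4-fold higher number from compound 1 to compound 2 (0.97 log units; beyond the scatter) lies beyond the scatter, as does the step of a 29-fold lower number from compound 2 to compound 3 (1.46 log units; beyond the scatter) to compound 3, which stands furthest away.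

Compound 4 `Cc1cc(C)c(-c2csc(NC(=O)/C=C/c3ccncc3)n2)c(C)c1` is not yet measured. It differs from compound 2 in one place: pyridin-4-yl in place of 4-fluorophenyl on a double-bonded chain carbon bound to a double-bonded chain carbon. Both measured steps that change the ring at this position bear on it. Going from compound 2, the exchange of fluoro for trifluoromethyl gave a 29-fold lower number from compound 2 to compound 3 (1.46 log units; beyond the scatter), and the exchange of 2-methoxyethoxy for fluoro gave a 9.4-fold higher number from compound 1 to compound 2 (0.97 log units; beyond the scatter). Among the compounds with values here, every replacement of the fluoro of compound 2 so far has lowered the number, though neither of those steps introduced a ring hetero atom, so they set no direct precedent for pyridin-4-yl. A lower number than compound 2 in this assay is therefore expected, likely of modest size, but with a wide range. For compound 4 the estimate is 5000 nM, between 1000 nM and 30000 nM, which is an expected step of a 2.8-fold lower number from compound 2 to compound 4 (0.45 log units; beyond the scatter).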

Compound 4, half-maximal inhibitory concentration: 9390 nM
Compound 4: middle estimate off by 1.9-fold (0.27 log units), on the low side; the measured number falls inside the stated range.
By their numbers in this assay, from the lowest: compound 3; then compound 1; then compounds 4 and 2 (each within the scatter of the next).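

In this assay, exchanging 4-fluorophenyl for pyridin-4-yl on a double-bonded chain carbon bound to a double-bonded chain carbon gives a 1.5-fold lower number from compound 2 to compound 4 (0.17 log units; within the scatter), so compound 2 and compound 4 cannot be told apart on this read-out. Within the data shown here, this is the first change that puts a hetero atom into this ring and brings a hydrogen-bond acceptor into the entering group, and, unlike the replacement giving a 29-fold lower number from compound 2 to compound 3 (1.46 log units; beyond the scatter), it produces no step beyond the scatter; replacing the fluoro of compound 2 therefore does not always shift the number, and the ring nitrogen in this placement, with no further substituent, leaves the read-out level with that of compound 2. No independent measurement is available that would explain this result.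

Going by these compounds, whether the outcome is specific to pyridin-4-yl remains open, since pyridin-3-yl and pyridin-2-yl would test other placements of the ring nitrogen. Also unresolved is how a dimethylamino group, a nitrile or a carboxylic acid on an aromatic carbon of this ring would compare with the trifluoromethyl of compound 3.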